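Trading a hydroxypropyl chain for bromine

The source may report more compounds than this note shows. Statements on the series, on what has been measured and on what is new or still open speak of the compounds shown alone.

Measured so far:
compound 1 `Cc1cccc(Nc2nc(-c3ccncc3CCCO)cs2)c1` — 6920 nM
compound 2 `Cc1cccc(Nc2nc(-c3ccncc3OCCCN(C)C)cs2)c1` — 2700 nM; 2750 nM (2 entries)

Within the data shown here, in a functional assay on RCC4 cells (Homo sapiens) for inhibition, read by XTT assay, with a stated time of 4 days (a higher number here means a weaker inhibitor, a lower number a stronger inhibitor), compound 1 gives 6920 nM and is the only compound represented by a single number; compound 2 appears with several entries, (the several entries of compound 2 in this assay, 2700 nM; 2750 nM (2 entries)). On the numbers shown, compound 1 sits at the higher end, the weaker of the two, with compound 2 giving the lower number.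

Compound 3 `Cc1cccc(Nc2nc(-c3ccncc3Br)cs2)c1` has not yet been measured. It differs from compound 1 by bromo in place of 3-hydroxypropyl on an aromatic carbon. Among the measured compounds shown here, no measured pair covers a change of this kind, so the size of the step cannot be read from the data. Given the loss of the hydrogen-bond donor and acceptor counted in that change, a modest move toward a weaker inhibitor, or none beyond the scatter, is expected in this assay. Compound 3 is expected to give 9000 nM, within a range from 3000 nM to 27000 nM. The expected step of a 1.3-fold higher number from compound 1 to compound 3 (0.11 log units; within the scatter) is therefore estimated to be small.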

Compound 3, half-maximal inhibitory concentration: 3980 nM
Compound 3: middle estimate off by 2.3-fold (0.35 log units), on the high side; the range from low to high includes it.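

In this assay, replacing the 3-hydroxypropyl chain with bromo on this aromatic carbon gives a 1.7-fold lower number from compound 1 to compound 3 (0.24 log units; within the scatter). At this position, then, a single bromine atom and a chain of 4 heavy atoms cannot be told apart in this read-out, even though the chain's hydrogen-bond donor and hydrogen-bond acceptor are lost in the change. Nothing among the data shown gives a reason for this outcome.

On these data alone, it remains open whether any group on this carbon can move the number beyond the scatter, for example a primary amine, a carboxylic acid or a longer alkyl chain. As far as these compounds go, it is also open whether plain hydrogen or a smaller halogen such as chlorine in place of the bromo would give a similar number.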